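Isopropyl for Methyl at the Chain Carbon of Compound 3

The compounds below may be only part of what the source reports. "The series", "measured", "known", "first", "only" and "open" are said of these compounds alone.

Compound 1, `C#Cc1ccc(-n2c(SC(C)c3ccccc3)nc3c(cnn3C)c2=O)cc1`: 520 nM
Compound 2, `CCC(Sc1nc2c(cnn2C)c(=O)n1-c1ccccc1)c1ccccc1`: 119 nM
Compound 3, `CC(Sc1nc2c(cnn2C)c(=O)n1-c1ccccc1)c1ccccc1`: 73 nM

Of the compounds shown here, three have been measured in an assay on isolated protein for inhibition of Retinaldehyde dehydrogenase 3 (Homo sapiens); on this read-out lower numbers stand for stronger inhibition and higher numbers for weaker inhibition. Compound 3 gives 73 nM, the lowest of the three numbers; compound 2 lies nearest, and the step of a 1.6-fold lower number from compound 2 to compound 3 (0.21 log units; within the scatter) stays within the scatter, while compound 1 lies furthest, with the step of a 7.1-fold lower number from compound 1 to compound 3 (0.85 log units; beyond the scatter) clearly beyond it.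

Compound 4, `CC(C)C(Sc1nc2c(cnn2C)c(=O)n1-c1ccccc1)c1ccccc1`, has not yet been measured. It differs from compound 3 in one place: isopropyl in place of methyl on a saturated chain carbon bound to an aromatic carbon and a sulfur. Going by the values given here, the one measured step at this chain carbon is a 1.6-fold lower number from compound 2 to compound 3 (0.21 log units; within the scatter), where the chain grew or shrank by one carbon without a change beyond the scatter. The move to isopropyl is a larger change than that, so a step in this assay of at most modest size is expected, more likely toward a higher number, though a step within the scatter is also plausible. The expected step is a 1.8-fold higher number from compound 3 to compound 4 (0.25 log units; within the scatter). Compound 4 is therefore estimated at 130 nM, with a range from 50 nM to 350 nM.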

Compound 4, half-maximal inhibitory concentration: 130 nM
The estimate for compound 4 equals the measured number at the digits printed, and the stated range covers the measured number.
By their numbers in this assay, from the lowest: compounds 3, 2 and 4 (each within the scatter of the next); then compound 1.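

With isopropyl in place of methyl on the saturated chain carbon bound to an aromatic carbon and a sulfur, this assay shows a 1.8-fold higher number from compound 3 to compound 4 (0.25 log units; within the scatter), so this larger branched group, with its 3 heavy atoms, gives no step beyond the scatter. The ethyl-bearing compound 2 and the isopropyl-bearing compound 4 also stay together, with methyl in place of hydrogen on a saturated chain carbon bound to two saturated chain carbons giving a 1.1-fold higher number from compound 2 to compound 4 (0.04 log units; within the scatter), so among compounds 2, 3 and 4 neither branching nor added carbons at this position separates the numbers.

The compounds shown leave open whether a phenyl ring, an amine or a carboxylic acid at this chain carbon would give a step beyond the scatter. They also leave open whether ethynyl on the aromatic carbon would have the same effect with isopropyl present. No evidence at hand bears on this result.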